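A further fluoro on compound 1

The compounds below may be only part of what the source reports. "The series", "measured", "known", "first", "only" and "open" are said of these compounds alone.

In a functional assay on the whole organism with Mus musculus as the target (a higher number here means that more compound is needed for the effect, a lower number that less compound is needed), compound 1 (`CN(C)C(=O)/C=C1\CCc2ccc(F)cc21`) gives > 100 mg/kg as its result, which is a limit of the assay and not a number. Compound 2 (`NC(=O)/C=C1\CCc2c(F)cccc21`) gives > 100 mg/kg in the same test, and that too is a limit. The measurements so far thus amount to the limit of > 100 mg/kg in this assay, at which 2 of the 2 values shown sit, and nothing finer. Compound 3 (`CN(C)C(=O)/C=C1\CCc2c(F)cc(F)cc21`) carries one change from compound 1: fluoro in place of hydrogen on an aromatic carbon (in words, fluoro in place of hydrogen on an aromatic carbon, ortho to a fused ring and meta to a fluoro group). Among the compounds with values here, no measured pair here isolates such a change, so the expectation rests on compound 1 alone. With compound 1 at > 100 mg/kg as its limit, no step beyond the usual scatter is expected in this assay and neither direction is favoured. The expected change is a number no higher from compound 1 to compound 3 (the limit leaves the size open) and it remains an estimate. For compound 3 the estimated dose is 100 mg/kg within an expected range of 40 mg/kg to 250 mg/kg and a result at the limit again would be no surprise.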

Compound 3, dose for half-maximal effect: 50 mg/kg
Compound 3: middle estimate off by 2.0-fold (0.30 log units), on the high side; low and high end bracket the measured number.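

With the added fluoro on an aromatic carbon, ortho to a fused ring and meta to a fluoro group, the compounds show an at least 2.0-fold lower number from compound 1 to compound 3 (0.30 log units; that floor lies within the scatter) in this assay. Compound 3 gives this series its first result that is a number and not a limit, so this position is the first place in the compounds shown where one change on the core of compound 1 moves the result off the limit, whereas the earlier compounds offered nothing finer to compare: the limit of > 100 mg/kg in this assay, at which 2 of the 3 values shown sit. Within the data shown here, only the floor of the step can be read, and as that floor lies within the usual scatter, the true size of the change stays unknown, though its direction is the one printed with the step.

The compounds shown leave open whether a chloro or a methoxy group at this same position would also give a number in this assay, and whether the result for fluoro here depends on the fluoro group it stands meta to. They also leave open whether a carboxylic acid or a longer chain in place of the amide of compound 3 would keep a result of this kind.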